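The compounds below may be only part of what the source reports. "The series", "measured", "known", "first", "only" and "open" are said of these compounds alone.

The series rests on one shared core, carried by compound 1 `CN(C)c1ccc2c(=O)c(C(=O)Nc3cc(F)cc(F)c3)cn(-c3ccc(OCCCCCCC[N+]45CCN(CC4)CC5)cc3Cl)c2n1` and compound 2 `CN(C)c1ccc2c(=O)c(C(=O)Nc3cc(F)cc(F)c3)cn(-c3ccc(OCCCCCCC[n+]4ccccc4)cc3Cl)c2n1`. In an assay on LX2 cells for inhibition of COL1A1 promoter (Homo sapiens), read by a luciferase reporter, with a stated time of 24 h, tested at 20 uM (a lower number here means a weaker effect, a higher number a stronger effect of the compound at the concentration tested), compound 1 gives 40.1%, whereas compound 2 is reported only as "not active" (no number reported), so no number fixes where compound 2 stands, and the two structures can be set against each other in words alone. Compound 3 `CN1CC[N+](C)(CCCCCCCOc2ccc(-n3cc(C(=O)Nc4cc(F)cc(F)c4)c(=O)c4ccc(N(C)C)nc43)c(Cl)c2)CC1` has not yet been measured in this assay. It differs from compound 2 in one place: a group of 8 heavy atoms (6 carbon, 2 nitrogen; one six-membered non-aromatic ring with 2 hetero atoms) in place of a group of 6 heavy atoms (5 carbon, 1 nitrogen; one six-membered aromatic ring with 1 hetero atom), on a saturated chain carbon, seven bonds along the chain from an oxygen on an aromatic ring. Compound 2 carries no number, so the size of the step to compound 3 cannot be stated in figures; a gain beyond the usual scatter in this assay is nonetheless expected rather than none, since compound 1 with 40.1% shows that a charged ring group at the end of this chain can go together with measurable inhibition. Compound 3 is therefore estimated to reach 30%, within 5% to 55%, in this assay.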

Compound 3, a percentage reported as inhibition, at one concentration (the size of the read-out at that concentration, not a potency): "not active" (no number reported)
The entry for compound 3 holds no number; there is nothing to compare the estimate with.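

In this assay, going by these compounds alone, compound 2 and compound 3 are both reported as not active without a number, so no step between them can be read. Nothing shown bears on this result. The compounds shown leave open what inhibition, if any, either compound gives in figures.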